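The compounds below may be only part of what the source reports. "The series", "measured", "known", "first", "only" and "open" are said of these compounds alone.

Measured compounds in a functional assay on HepG2 cells (Homo sapiens) for cytotoxicity, read by MTT assay, with a stated time of 72 h; on this read-out lower numbers stand for stronger inhibition and higher numbers for weaker inhibition:
compound 1 `CN1[C@@H]2c3[nH]c4ccccc4c3C[C@H]1[C@H](C#N)N1[C@@H](CN3C(=O)c4ccccc4C3=O)c3[nH]c4ccccc4c3C[C@@H]21` gives 20 nM
compound 2 `CN1[C@@H]2c3[nH]c4ccccc4c3C[C@H]1[C@H](C#N)N1[C@@H](CNC(=O)c3ccc(Cl)cc3)c3[nH]c4ccccc4c3C[C@@H]21` gives 350 nM

Among the compounds with values here, compound 2 holds the higher of the two numbers in this assay, and its only neighbour is compound 1; the step of an 18-fold higher number from compound 1 to compound 2 (1.24 log units; beyond the scatter) lies beyond the scatter, and it exchanged the whole group on the saturated chain carbon of the shared core, so it says little about a change confined to the aryl ring of the amide.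

Compound 3 `CN1[C@@H]2c3[nH]c4ccccc4c3C[C@H]1[C@H](C#N)N1[C@@H](CNC(=O)c3cccc4c3CCCC4)c3[nH]c4ccccc4c3C[C@@H]21` differs from compound 2 by 1,2,3,4-tetrahydronaphthalen-5-yl in place of 4-chlorophenyl on a carbonyl carbon. No measured step changes only this aryl ring, so nothing shown tells how the number moves when the chlorine-bearing ring becomes the fused bicyclic one. Within the data shown here, the one step that is known is large, which shows this assay does respond to changes in this part of the molecule, but its direction for compound 3 cannot be read from it.

Compound 3 is therefore expected to stay near compound 2, with an estimated step of a 1.2-fold lower number from compound 2 to compound 3 (0.07 log units; within the scatter) that may fall within the scatter. The estimate for compound 3 is 300 nM, with a range from 90 nM to 1000 nM.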

Compound 3, half-maximal inhibitory concentration: 540 nM
Estimate against measurement, compound 3: 1.8-fold (0.26 log units) below, and the stated range covers the measured number.
By their numbers in this assay, from the lowest: compound 1; then compounds 2 and 3 (each within the scatter of the next).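

In this assay, putting 1,2,3,4-tetrahydronaphthalen-5-yl in place of 4-chlorophenyl on the carbonyl carbon gives a 1.5-fold higher number from compound 2 to compound 3 (0.19 log units; within the scatter) and so stays within the scatter, making this the first step shown that is confined to the aryl group of the amide. Losing the chlorine and gaining a six-membered non-aromatic ring of carbon together leave compound 2 and compound 3 indistinguishable in this read-out, so this exchange of aryl groups does not show the sensitivity seen in the much larger step an 18-fold higher number from compound 1 to compound 2 (1.24 log units; beyond the scatter) and does not close that gap. No measurement is available that would explain why these two aryl groups read alike.

The compounds shown leave open whether chlorine and the fused ring each have little effect alone or whether their separate contributions merely offset one another, which an unsubstituted phenyl group on the same carbonyl carbon could help to separate. They also leave open whether the number would stay within this range with a more different group there, such as a pyridine ring, an aryl ring carrying a carboxylic acid or an amine, or a longer saturated chain.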